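The compounds below may be only part of what the source reports. "The series", "measured", "known", "first", "only" and "open" are said of these compounds alone.

In a functional assay on HeLa cells (Homo sapiens) for inhibition, read by MTT assay, with a stated time of 48 h (on this read-out lower numbers stand for stronger inhibition and higher numbers for weaker inhibition), three compounds sharing one core have been measured. Compound 1 `Brc1ccc2[nH]cc(C(c3ccccc3)c3c[nH]c4ccc(Br)cc34)c2c1` gives 900 nM, compound 2 `Oc1ccc(C(c2c[nH]c3ccc(Br)cc23)c2c[nH]c3ccc(Br)cc23)cc1` gives 4000 nM and compound 3 `COc1ccc(C(c2c[nH]c3ccc(Br)cc23)c2c[nH]c3ccc(Br)cc23)cc1` gives 5500 nM. Compound 2 is level with compound 3 within the usual scatter, and its number is clearly higher than that of compound 1, which means weaker inhibition.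

The next compound, compound 4 `COc1ccc(C(c2c[nH]c3ccc(Br)cc23)c2c[nH]c3ccc(Br)cc23)cc1OC`, has not yet been measured. Its change from compound 2 is 3,4-dimethoxyphenyl in place of 4-hydroxyphenyl on a saturated chain carbon bound to two aromatic carbons.

For the measured compounds named here, three measured steps bear on this change. Adding a hydroxy group gave a 4.4-fold higher number from compound 1 to compound 2 (0.65 log units; beyond the scatter), and adding a methoxy group gave a 6.1-fold higher number from compound 1 to compound 3 (0.79 log units; beyond the scatter), both modest and beyond the scatter. Replacing the hydroxy hydrogen with methyl, which is part of the new change, gave only a 1.4-fold higher number from compound 2 to compound 3 (0.14 log units; within the scatter), within the scatter. Going by the values given here, the data contain no example of a second methoxy group being added, so that part of the change remains uncertain. The modest cost of the one methoxy addition on record suggests that any movement will be upward, though small. The expected step is a 1.5-fold higher number from compound 2 to compound 4 (0.18 log units; within the scatter). For compound 4 the estimate is 6000 nM, with an expected range from 2500 nM to 14000 nM.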

Compound 4, half-maximal inhibitory concentration: 6100 nM
For compound 4 the middle estimate is 1.0-fold (0.01 log units) below the measured one; low and high end bracket the measured number.
By their numbers in this assay, from the lowest: compound 1; then compounds 2, 3 and 4 (each within the scatter of the next).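

In this assay, a second methoxy group on the ring makes no readable difference (a 1.1-fold higher number from compound 3 to compound 4 (0.04 log units; within the scatter)), and the full exchange of 4-hydroxyphenyl for 3,4-dimethoxyphenyl on the saturated chain carbon bound to two aromatic carbons also stays within the scatter (a 1.5-fold higher number from compound 2 to compound 4 (0.18 log units; within the scatter)), even though the entering group is larger and has no hydrogen-bond donor. Set against the plain phenyl group of compound 1, the dimethoxy ring gives a modest step to weaker inhibition (a 6.8-fold higher number from compound 1 to compound 4 (0.83 log units; beyond the scatter)), so all three substituted rings shown now lie on the weaker side of compound 1, while the three remain level with one another. Nothing measured here explains why these rings differ from plain phenyl or why the extra methoxy group makes no readable difference.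

The compounds shown leave open whether other groups on this ring, such as an amine, a carboxylic acid or a fluorine atom, would also give weaker inhibition than plain phenyl. They also leave open whether a longer chain on the ring oxygen, such as ethoxy or propoxy, would stay level with methoxy.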